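Dibromobenzamide series: thiosulfate sulfurtransferase inhibition, working notes

The compounds below may be only part of what the source reports. "The series", "measured", "known", "first", "only" and "open" are said of these compounds alone.

Measured in an assay on isolated protein for inhibition of thiosulfate sulfurtransferase (Homo sapiens), with a stated time of 60 min, in the absence of a further agent; a higher number here means a weaker inhibitor, a lower number a stronger inhibitor:
compound 1 `O=C(Nc1ccc(Sc2nc3ccccc3s2)c(Cl)c1)c1cc(Br)cc(Br)c1`: > 100000 nM, a limit of this assay
compound 2 `O=C(Nc1cccc(Cl)c1)c1cc(Br)cc(Br)c1`: > 100000 nM, a limit of this assay
compound 3 `O=C(Nc1cccc(Cl)c1)c1cccc(Br)c1`: > 100000 nM, a limit of this assay

Compound 1 stands only at the limit; no number is known for it. All three measured values sit at the limit of > 100000 nM in this assay, at which 3 of the 3 values shown sit. Within the data shown here, the single one-place step, a step that the two limits leave unreadable from compound 2 to compound 3, cannot be read: both of its ends are limits. Compound 4 `COc1c(Br)cccc1C(=O)Nc1ccc(Sc2nc3ccccc3s2)c(Cl)c1` differs from compound 1 by a group of 9 heavy atoms (7 carbon, 1 oxygen, 1 bromine; one six-membered aromatic ring of carbon only) in place of a group of 8 heavy atoms (6 carbon, 2 bromine; one six-membered aromatic ring of carbon only), on a carbonyl carbon. Among the measured compounds shown here, no measured step bears on this change, and with every value at the limit neither size nor direction can be read from the series. Compound 4 is estimated at 80000 nM, with a range of 10000 nM to 300000 nM. This estimate means an expected step of an at least 1.2-fold lower number from compound 1 to compound 4 (0.09 log units; that floor lies within the scatter).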

Compound 4, half-maximal inhibitory concentration: > 100000 nM
Compound 4: no number, only a limit; the forecaster's own chance of this, stated with the estimate: 60%; at least 1.2-fold (0.09 log units) between middle value and limit.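

Compound 1 and compound 4 both stand only at a limit, and no new step can be read between them. The compounds shown leave open whether any change to the shared core gives a readable number, with every value so far at one limit: the limit of > 100000 nM in this assay, at which 4 of the 4 values shown sit.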